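Swapping Methyl for Chloro on an Inactive Sulfonamide

A few compounds are considered here, and "the series" means these few. Any claim that something is new, unique, unknown or untested is made for them only; others in the source may bear on it.

Measured so far in an assay on isolated protein for inhibition of malate dehydrogenase, mitochondrial (Sus scrofa), with stated times of 45 min and 30 min; a higher number here means a weaker inhibitor, a lower number a stronger inhibitor:
- compound 1, `Cc1ccc(S(=O)(=O)Nc2ccc(-c3nc4ccccc4o3)cc2)cc1`, gives > 63000 nM
- compound 2, `O=S(=O)(Nc1ccc2oc(-c3ccccc3)nc2c1)c1ccc(Cl)c(C(F)(F)F)c1`, gives > 63000 nM
- compound 3, `CS(=O)(=O)Nc1ccc2oc(-c3ccccc3)nc2c1`, gives > 63000 nM

Compound 1 stands at the limit of this assay: its value is a limit, not a number. Among the measured compounds shown here, the same holds for compound 2 and for compound 3, so every value shown is the limit of > 63000 nM in this assay, at which 3 of the 3 values shown sit, and no step between measured compounds can be read off.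

Compound 4, `O=S(=O)(Nc1ccc(-c2nc3ccccc3o2)cc1)c1ccc(Cl)cc1`, differs from compound 1 in one place: chloro in place of methyl on an aromatic carbon. For the measured compounds named here, no measured step exists for such a change here. Since every value shown sits at the limit, compound 4 is expected to behave like compound 1, with no step beyond the scatter, and to land at or near the limit again.

Compound 4 is estimated at 90000 nM in this assay, with a range from 30000 nM to 300000 nM. That estimate means a step that the limit leaves unreadable from compound 1 to compound 4, expected to be flat.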

Compound 4, half-maximal inhibitory concentration: > 63000 nM
Compound 4: only a limit was reported; the forecaster's own chance of this, stated with the estimate: 85%; the middle value lies beyond the limit too.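

In this assay compound 4 gives > 63000 nM, which is a limit and not a number. Among the compounds shown here, compound 1 also has only a limit, so no step from compound 1 to compound 4 can be read. The compounds shown leave open what structure would give a measurable value: the limit of > 63000 nM in this assay, at which 4 of the 4 values shown sit.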